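This account rests on a few compounds, and the source may have more. Where it says the series, first, only, none or still open, it means among the compounds named here.

Among the measured compounds shown here, compound 1 `CCOc1ccccc1-c1ccc(-c2nc3cnccc3c(N[C@H](CC)C(=O)NS(C)(=O)=O)c2C#N)cc1` is one of three compounds measured in a physicochemical assay for lipophilicity, read by HPLC, at pH 7.5; on this read-out lower numbers stand for lower lipophilicity and higher numbers for higher lipophilicity. In this assay compound 1 gives 2.2, the lowest of the three numbers. Compound 2 `CC[C@@H](Nc1c(C#N)c(-c2ccc(-c3ccc(Cl)cc3)cc2)nc2cnccc12)C(N)=O` gives 3.1 in this assay, and compound 3 `CC[C@@H](Nc1c(C#N)c(-c2ccc(-c3ccccc3Cl)cc2)nc2cnccc12)C(N)=O` gives 2.9; both of these stand beyond the scatter above compound 1. For the measured compounds named here, the only step between measured compounds that differ in one place is a number 0.20 log units lower from compound 2 to compound 3 (within the scatter), where 2-chlorophenyl takes the place of 4-chlorophenyl on an aromatic carbon.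

Compound 4 `CCOc1ccccc1-c1ccc(-c2nc3cnccc3c(N[C@@H]3CCOC3=O)c2C#N)cc1` has not yet been measured in this assay. It differs from compound 1 in one place:

a group of 6 heavy atoms (4 carbon, 2 oxygen; one five-membered non-aromatic ring with 1 hetero atom) in place of a group of 10 heavy atoms (5 carbon, 1 nitrogen, 3 oxygen, 1 sulfur; no ring), on a nitrogen on an aromatic ring

Going by the values given here, no measured step touches this kind of change; the single measured step alters a different part of the molecule and is in any case within the scatter. What can be said is that compounds 2 and 3, which do not carry the group that leaves here, both give numbers clearly higher than compound 1. On that basis an upward step in this assay is expected, a number 1.10 log units higher from compound 1 to compound 4 (beyond the scatter), though with wide uncertainty. Compound 4 is therefore estimated to give 3.3 in this assay, within a range from 2.7 to 3.9.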

Compound 4, distribution coefficient: 2.7
Compound 4: the middle estimate sits 0.60 log units above what was measured, within the range that was stated.
By their numbers in this assay, from the lowest: compound 1; then compounds 4, 3 and 2 (each within the scatter of the next, the first and the last beyond it).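

On a nitrogen on an aromatic ring, putting 2-oxooxolan-3-yl in place of the open-chain group of 10 heavy atoms gives, in this assay, a number 0.50 log units higher from compound 1 to compound 4 (beyond the scatter): a modest step, but one beyond the scatter. Among the compounds shown here, the earlier compounds offered only a step on the chlorophenyl group that stayed within the scatter, so this is the first sign that a change at this nitrogen can move the number measurably. For the compounds shown here, the single swap alters several things together, since the entering group brings a five-membered ring, has 0 hydrogen-bond donors in place of 1, and carries no sulfur or nitrogen, and no measurement here links the step to any one of these features.

The compounds shown therefore leave open which of these features accounts for the step, a question that a carboxylic acid or an open-chain methyl ester on the same nitrogen could help to address. They also leave open how a six-membered lactone ring, or the opposite stereocentre in the 2-oxooxolan-3-yl group, would read in this assay.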